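Dimethylamino for Propylsulfanyl: Cytotoxicity Limits All Round

The compounds below may be only part of what the source reports. "The series", "measured", "known", "first", "only" and "open" are said of these compounds alone.

Three compounds sharing one core were tested in an ADME assay on Akata cells (Homo sapiens) for cytotoxicity, with a stated time of 7 days; on this read-out lower numbers stand for higher toxicity in this test and higher numbers for lower toxicity in this test. Compound 1 `CCCCSc1nc(N)nc2c1ncn2/C=C1/CC1(CO)CO` gives > 20000 nM, which is a limit of the assay rather than a number. Compound 2 `Nc1nc(NC2CCCCC2)c2ncn(/C=C3/CC3(CO)CO)c2n1` gives > 24000 nM, also a limit. Compound 3 `CCCSc1nc(N)nc2c1ncn2/C=C1/CC1(CO)CO` gives > 20000 nM, again a limit. Compound 3 thus stands where every measured compound stands, at a limit with no readable separation from the others. The steps a step that the two limits leave unreadable from compound 1 to compound 2, a step that the two limits leave unreadable from compound 1 to compound 3 and a step that the two limits leave unreadable from compound 2 to compound 3 are all unreadable. Compound 4 `CN(C)c1nc(N)nc2c1ncn2/C=C1/CC1(CO)CO` differs from compound 3 by dimethylamino in place of propylsulfanyl on an aromatic carbon. Among the compounds with values here, no measured step yields a size, so no shift beyond the scatter is expected in this assay. Compound 4 is expected to give 25000 nM, within 12000 nM to 60000 nM, likely as a limit again. That expectation means a step that the limit leaves unreadable from compound 3 to compound 4.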

Compound 4, half-maximal cytotoxic concentration: > 24000 nM
Compound 4: only a limit was reported; the forecaster's own chance of this, stated with the estimate: 85%; the middle value lies beyond the limit too.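

The steps linking compound 4 with compound 1, compound 2 and compound 3 cannot be read in this assay, where all four compounds give only limits. Still open, on these data alone, is whether the group on the aromatic carbon changes cytotoxicity at all.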